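A Halophenyl Swap on a Weak Antiproliferative Core

The source may report more compounds than this note shows. Statements on the series, on what has been measured and on what is new or still open speak of the compounds shown alone.

For the measured compounds named here, compound 1 `O=c1nc2oc(C3CC3)c(C#CC3CC3)c2cn1Cc1cn(-c2ccccc2F)nn1` is one of two compounds measured in a functional assay on CFPAC-1 cells (Homo sapiens) for antiproliferative activity, read by MTT assay, with a stated time of 72 h; on this read-out higher numbers stand for weaker inhibition and lower numbers for stronger inhibition. In this assay, going by the values given here, compound 1 gives 54500 nM, the only plain number in the set. The second compound, compound 2 `CCCCCCC#Cc1c(CCCCCC)oc2nc(=O)n(Cc3cn(-c4ccc(F)cc4)nn3)cc12`, carries different groups on the shared core and a 4-fluorophenyl on the ring nitrogen. In this assay compound 2 reaches only a limit, > 100000 nM. That limit is the limit of > 100000 nM in this assay, at which 1 of the 2 values shown sits. Compound 3 `O=c1nc2oc(C3CC3)c(C#CC3CC3)c2cn1Cc1cn(-c2ccc(Cl)cc2)nn1` keeps the core of compound 1 and changes only the group on the aromatic nitrogen: 4-chlorophenyl in place of 2-fluorophenyl on an aromatic nitrogen. Among the compounds with values here, no measured pair isolates such a change, so the step is expected to be small, with no direction beyond the scatter. The expected step is a 1.1-fold lower number from compound 1 to compound 3 (0.04 log units; within the scatter). Compound 3 is estimated at 50000 nM, within 20000 nM to 120000 nM.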

Compound 3, half-maximal inhibitory concentration: 35400 nM
For compound 3 the middle estimate is 1.4-fold (0.15 log units) above the measured one; measured number inside the range.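

In this assay, the change to 4-chlorophenyl in place of 2-fluorophenyl on an aromatic nitrogen gives a 1.5-fold lower number from compound 1 to compound 3 (0.19 log units; within the scatter) and so leaves the number essentially where it was. For the compounds shown here, this is the first pair in the set that differs in one place, so the group at this position can now be read on its own, and this exchange of one halophenyl group for another moves the read-out by no more than the scatter. None of the data given bear on why the two groups read alike.

On these data alone, whether an amine or a carboxylic acid in place of the halogen would move the number beyond the scatter stays open. As far as these compounds go, the effect of the groups on the shared core also stays open, since compound 2 differs from compound 1 in more than one place.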